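The source may hold more compounds than are shown below. What is called first, only, known or untested is meant among the compounds shown, and "the series" means these compounds.

Measured so far in a functional assay on A549 cells (Homo sapiens) for cytotoxicity, read by MTT assay, with a stated time of 72 h; on this read-out higher numbers stand for weaker inhibition and lower numbers for stronger inhibition:
compound 1 `O=C(Nc1nnc(-c2cccc(O)c2O)s1)c1ccccc1`: 12300 nM
compound 2 `O=C(Nc1nnc(-c2cccc(O)c2O)s1)C1CCCCC1`: 11000 nM
compound 3 `O=C(COc1ccccc1)Nc1nnc(-c2cccc(O)c2O)s1`: 10500 nM

Compound 3 gives the lowest of the three numbers, yet within the scatter of both others: a 1.0-fold lower number from compound 2 to compound 3 (0.02 log units; within the scatter) and a 1.2-fold lower number from compound 1 to compound 3 (0.07 log units; within the scatter), as is a 1.1-fold lower number from compound 1 to compound 2 (0.05 log units; within the scatter). All three differ only in the group on the carbonyl carbon.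

Compound 4 `O=C(COc1ccccc1)Nc1nnc(-c2ccc(O)c(O)c2)s1` changes a different part: 3,4-dihydroxyphenyl in place of 2,3-dihydroxyphenyl on an aromatic carbon. Within the data shown here, no measured step alters the dihydroxyphenyl group, so none bears on this change, and the acyl variations give no guidance on it. Without precedent, no step beyond the scatter is expected, though the uncertainty is wide. Compound 4 is therefore expected at 10500 nM, range 3500 nM to 32000 nM, a step of no change at the digits printed from compound 3 to compound 4 (within the scatter) in this assay.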

Compound 4, half-maximal inhibitory concentration: 21200 nM
Beside the measured number, compound 4's estimate is 2.0-fold (0.31 log units) below it; the measured number falls inside the stated range.
By their numbers in this assay, from the lowest: compounds 3, 2, 1 and 4 (each within the scatter of the next, the first and the last beyond it).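

In this assay, among these compounds, 3,4-dihydroxyphenyl in place of 2,3-dihydroxyphenyl gives a 2.0-fold higher number from compound 3 to compound 4 (0.31 log units; beyond the scatter) and is a modest step, the only single-place change so far to pass beyond the scatter. The number therefore responds to how the two hydroxyl groups are arranged on this ring, which the acyl changes among compound 1, compound 2 and compound 3 could not show. No available evidence bears on this step.

From the compounds shown here alone, whether the step holds with phenyl or cyclohexyl on the carbonyl carbon remains open. So does the outcome of replacing either hydroxyl group with a methoxy group or an amine.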